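A few compounds are considered here, and "the series" means these few. Any claim that something is new, unique, unknown or untested is made for them only; others in the source may bear on it.

The series rests on a shared core carrying an amino group and, on the five-membered ring, either a nitrile or a carboxamide. Compound 1 `CCCn1cc(C(N)=O)c2c(N)ncnc21` bears a propyl chain on the ring nitrogen together with the carbamoyl group. In a functional assay on KB cells (Homo sapiens) for cytotoxicity (on this read-out lower numbers stand for stronger inhibition and higher numbers for weaker inhibition), compound 1 gives 100000 nM, which sits at the weak end of the read-out. Compound 2 `Cc1ccc(Cn2cc(C#N)c3c(N)ncnc32)cc1` carries a 4-methylbenzyl group on the ring nitrogen and the cyano group. In this assay compound 2 reaches only the limit of > 100000 nM, so no number is known for it, as set out in the limit of > 100000 nM in this assay, at which 1 of the 2 values shown sits. Compound 3 `Cc1ccc(Cn2cc(C(N)=O)c3c(N)ncnc32)cc1` keeps the 4-methylbenzyl group of compound 2 and changes the substituent on the five-membered ring: carbamoyl in place of cyano on an aromatic carbon. Among the compounds with values here, no measured pair in the set isolates this change, so the size of the step is open; it is expected to stay within the scatter, with no clear direction. For compound 3 the estimate in this assay is 100000 nM, between 50000 nM and 200000 nM, which corresponds to an expected step of a number no higher from compound 2 to compound 3 (the limit leaves the size open).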

Compound 3, half-maximal inhibitory concentration: > 100000 nM
Compound 3: only a limit was reported (the forecaster's own chance of this, stated with the estimate: 50%); the middle value sits exactly at the limit.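

With carbamoyl in place of cyano on the aromatic carbon, compound 3 still yields no number in this assay, and its > 100000 nM is a limit. This leaves a number no lower from compound 1 to compound 3 (the limit leaves the size open). The steps linking compound 3 to compound 2 and to compound 1 cannot be read in size, so the swap of cyano for carbamoyl has no readable effect at this position. What the result adds is that, with the 4-methylbenzyl group on the ring nitrogen, both the cyano and the carbamoyl compound stand at the limit: the limit of > 100000 nM in this assay, at which 2 of the 3 values shown sit.

The compounds shown leave open whether a different group on this aromatic carbon, such as a carboxylic acid or an aminomethyl group, would give a value inside the range of the read-out. They also leave open whether a longer chain on the ring nitrogen would do so.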